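This account rests on a few compounds, and the source may have more. Where it says the series, first, only, none or still open, it means among the compounds named here.

Values in a functional assay (microsomes, liver) with Rattus norvegicus as the target (a higher number here means a weaker inhibitor, a lower number a stronger inhibitor), for the measured compounds
- compound 1 `Cc1c(C)c2c(c(N)c1N)CC(C)(C)O2` gives 300 nM
- compound 2 `Cc1c(C)c2c(c(C)c1N)CC(C)(CSc1ccccc1)O2` gives 270 nM
- compound 3 `Cc1c(C)c2c(c(C)c1N)CC(C)(CSc1ccc(F)cc1)O2` gives 220 nM

All three values lie within the usual scatter of one another, so compound 2 at 270 nM cannot be separated from the other two on these numbers. Compound 4 `COCC1(C)Cc2c(C)c(N)c(C)c(C)c2O1` has not yet been measured. It carries methoxy in place of phenylsulfanyl on a saturated chain carbon bound to a saturated ring carbon, a change from compound 2 counted as methoxy in place of phenylsulfanyl on a saturated chain carbon bound to a saturated ring carbon in full.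

Among the measured compounds shown here, the one measured step, a 1.2-fold lower number from compound 2 to compound 3 (0.09 log units; within the scatter) (fluoro in place of hydrogen on an aromatic carbon), stays within the scatter. It keeps the phenylsulfanyl group, so it is only a loose guide. Compound 1 also lacks phenylsulfanyl, differs elsewhere too, and gives 300 nM in the same range. No step beyond the scatter is therefore expected in this assay for this change, although no direct test exists. The estimated step is a 1.3-fold higher number from compound 2 to compound 4 (0.11 log units; within the scatter) and no more than that. For compound 4 the estimate is 350 nM with 120 nM to 1000 nM as its expected range.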

Compound 4, half-maximal inhibitory concentration: 300 nM
For compound 4 the middle estimate is 1.2-fold (0.07 log units) above the measured one, within the range that was stated.
By their numbers in this assay, from the lowest: compounds 3, 2, 1 and 4 (each within the scatter of the next).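

In this assay, putting methoxy in place of phenylsulfanyl on a saturated chain carbon bound to a saturated ring carbon gives a 1.1-fold higher number from compound 2 to compound 4 (0.05 log units; within the scatter) and so leaves the number within the scatter. Among the compounds shown here, this is the first one-place change that removes the whole phenylsulfanyl group: a group of 7 heavy atoms, including a six-membered aromatic ring and a sulfur, gives way to one of 2 heavy atoms without a step beyond the scatter. For the compounds shown here, the only earlier one-place step, a 1.2-fold lower number from compound 2 to compound 3 (0.09 log units; within the scatter), kept that group and could not show this, and no outside evidence explains the result.

From the compounds shown here alone, it remains open whether an amine, a carboxylic acid or a longer chain at this place would also stay within the scatter. Nor do these compounds show which group here, if any, would move the number beyond it.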